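Adding Fluorine to the Least Potent of Three Compounds

A few compounds are considered here, and "the series" means these few. Any claim that something is new, unique, unknown or untested is made for them only; others in the source may bear on it.

Compound 1 `COc1ccc2c(c1)C(n1ccccc1=O)=CC(C)(C)O2`: 5.99
Compound 2 `CC1(C)C=C(n2ccccc2=O)c2cc(O)ccc2O1`: 5.31
Compound 3 `CC1(C)C=C(n2ccccc2=O)c2cc(OCC(=O)c3ccccc3)ccc2O1`: 4.69

In a functional assay (trachea) with Rattus norvegicus as the target (on this read-out higher numbers stand for higher potency (the scale is a negative logarithm) and lower numbers for lower potency), compound 3 has the lowest number of the three, both a number 1.30 log units lower from compound 1 to compound 3 (beyond the scatter) and a number 0.62 log units lower from compound 2 to compound 3 (beyond the scatter) pointing downward beyond the scatter. Compound 4 `CC1(C)C=C(n2ccccc2=O)c2cc(OCC(=O)c3ccc(F)cc3)ccc2O1` differs from compound 3 by one change, (fluoro in place of hydrogen on an aromatic carbon), para to a large group on the phenyl of the benzoylmethyl group. Going by the values given here, the measured steps, a number 0.68 log units lower from compound 1 to compound 2 (beyond the scatter), a number 1.30 log units lower from compound 1 to compound 3 (beyond the scatter) and a number 0.62 log units lower from compound 2 to compound 3 (beyond the scatter), all alter what sits on the oxygen of the aromatic ring; none touches that phenyl, so no measured step bears on this change. Compound 4 is therefore expected to stay within the scatter of compound 3, no change at the digits printed from compound 3 to compound 4 (within the scatter). The estimate for compound 4 in this assay is 4.69, ranging from 4.2 to 5.2.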

Compound 4, logarithm of the reciprocal of the active concentration, log(1/C): 4.77
Compound 4: middle estimate off by 0.08 log units, on the low side; the range from low to high includes it.
By their numbers in this assay, from the lowest: compounds 3 and 4 (each within the scatter of the next); then compound 2; then compound 1.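

In this assay, going by these compounds alone, fluoro on the phenyl of the benzoylmethyl group is the first change at this place, and it leaves the number unmoved (a number 0.08 log units higher from compound 3 to compound 4 (within the scatter)). The drop that came with the benzoylmethyl group remains with the fluorinated group, both against the free hydroxyl (a number 0.54 log units lower from compound 2 to compound 4 (beyond the scatter)) and against the methoxy (a number 1.22 log units lower from compound 1 to compound 4 (beyond the scatter)). No outside evidence bears on this result. Whether a methoxy, an amine or a carboxylic acid at this place would shift the number stays open, since fluoro is the only replacement for hydrogen shown here.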